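A few compounds are considered here, and "the series" means these few. Any claim that something is new, unique, unknown or untested is made for them only; others in the source may bear on it.

Measured compounds:
Compound 1 `Cc1c(CCCC(=O)O)c2cccc(/C=C/c3ccc(OCCCCc4c(F)cc(F)c(F)c4F)cc3)c2n1CC(=O)O` gives 0.3 10^-6 cm/s.
Compound 2 `Cc1c(F)cccc1CCCCOc1ccc(/C=C/c2cccc3c(CCCC(=O)O)c(C)n(CC(=O)O)c23)cc1` gives 1.5 10^-6 cm/s.

Both values come from a physicochemical assay for permeability, using PAMPA, with a stated time of 4 h, at pH 7.4, tested at 50 uM; a higher number here means that the compound crosses the layer faster, a lower number that the compound crosses the layer more slowly. Among these two numbers compound 2 stands highest; its only neighbour is compound 1, and the step of a 5.0-fold higher number from compound 1 to compound 2 (0.70 log units; beyond the scatter) separates them. Within the data shown here, that step concerns the aryl group at the end of the butoxy chain, 3-fluoro-2-methylphenyl in place of 2,3,4,6-tetrafluorophenyl, and it is the single measured step available.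

Compound 3 `Cc1c(F)cccc1CCCCOc1ccc(/C=C/c2cccc3c(CCCC(=O)O)cn(CC(=O)O)c23)cc1` keeps the chain and aryl group of compound 2 and differs from it only in the shared core: hydrogen in place of methyl on an aromatic carbon. Among the measured compounds shown here, no measured step touches this part of the molecule, so the one measured step gives no direct guide to it. The change removes a single carbon with no donor, acceptor or charge, and on that basis a shift in this assay beyond the scatter is not expected, in either direction. Compound 3 is therefore estimated at 1.2 10^-6 cm/s, within a range of 0.5 10^-6 cm/s to 3 10^-6 cm/s, a step of a 1.3-fold lower number from compound 2 to compound 3 (0.10 log units; within the scatter) that is expected to lie within the scatter.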

Compound 3, apparent permeability: < 0.05 10^-6 cm/s
Compound 3 was reported as a limit; the forecaster's own chance of this, stated with the estimate: 5%; middle value at least 24-fold (1.38 log units) from the limit.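

Replacing methyl with hydrogen on this aromatic carbon of the five-membered aromatic ring, next to the ring nitrogen, gave an at least 30-fold lower number from compound 2 to compound 3 (1.47 log units; beyond the scatter). Compound 3 stands in this assay as a limit and not as a number: the limit of < 0.05 10^-6 cm/s in this assay, at which 1 of the 3 values shown sits. Among these compounds, the only earlier step changed the aryl group at the end of the chain, so this is the first sign that the shared core also matters in this assay, and that the loss of a single carbon, with no donor, acceptor or charge involved, can produce a step beyond the scatter at this position.

The compounds shown cannot tell whether methyl is specifically required here, or whether an ethyl, a methoxy or a chlorine on the same carbon would keep the number near that of compound 2, and they include no pair that tests the same change with the 2,3,4,6-tetrafluorophenyl group of compound 1 in place of 3-fluoro-2-methylphenyl. They also include no measured property that accounts for the step, so its cause remains open.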